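The source may report more compounds than this note shows. Statements on the series, on what has been measured and on what is new or still open speak of the compounds shown alone.

Compound 1 `COc1cc(Nc2nc3ccccc3nc2S(=O)(=O)c2ccc(C)cc2)cc(OC)c1` gives 20 nM in a functional assay on HL-60 cells (Homo sapiens) for cytotoxicity, read by MTT assay, with a stated time of 72 h; a lower number here means a stronger inhibitor, a higher number a weaker inhibitor. Compound 2 `Cc1ccc(S(=O)(=O)c2nc3ccccc3nc2Nc2ccc(N)cc2)cc1` differs from it by 4-aminophenyl in place of 3,5-dimethoxyphenyl on a nitrogen on an aromatic ring and gives 1220 nM in this assay, a change that brought a 61-fold higher number from compound 1 to compound 2 (1.79 log units; beyond the scatter). Compound 3 `COc1ccc(S(=O)(=O)c2nc3ccccc3nc2Nc2cc(OC)cc(OC)c2)cc1` has a different core, differing from compound 1 by methoxy in place of methyl on an aromatic carbon; in this assay compound 3 gives 1710 nM, which is an 86-fold higher number from compound 1 to compound 3 (1.93 log units; beyond the scatter). Compound 4 `COc1ccc(S(=O)(=O)c2nc3ccccc3nc2Nc2ccc(N)cc2)cc1` is not yet measured and differs from compound 3 by 4-aminophenyl in place of 3,5-dimethoxyphenyl on a nitrogen on an aromatic ring, the same change that was made from compound 1 to compound 2, at a place described in identical words. Within the data shown here, only that one earlier instance exists, so the size on the second core is uncertain. Because a 61-fold higher number from compound 1 to compound 2 (1.79 log units; beyond the scatter) was seen, a step in the same direction is expected for compound 4, about a 12-fold higher number from compound 3 to compound 4 (1.07 log units; beyond the scatter), though it may be damped since compound 3 already gives 1710 nM. Compound 4 is therefore estimated to give 20000 nM in this assay, likely between 4000 nM and 100000 nM.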

Compound 4, half-maximal inhibitory concentration: 710 nM
Beside the measured number, compound 4's estimate is 28-fold (1.45 log units) above it, outside the stated range (below it).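

In this assay, 4-aminophenyl in place of 3,5-dimethoxyphenyl on the core of compound 3 gave a 2.4-fold lower number from compound 3 to compound 4 (0.38 log units; beyond the scatter), so the change did not carry over from the core of compound 1 in size or direction: the same change on two cores in this assay, a 61-fold higher number (1.79 log units; beyond the scatter) from compound 1 to compound 2 and a 2.4-fold lower number (0.38 log units; beyond the scatter) from compound 3 to compound 4, 150-fold (2.17 log units) apart, beyond the scatter of two such steps

Methoxy in place of methyl likewise gave a 1.7-fold lower number from compound 2 to compound 4 (0.24 log units; within the scatter) with 4-aminophenyl on the nitrogen, unlike the large step seen with 3,5-dimethoxyphenyl: the same change on two cores in this assay, an 86-fold higher number (1.93 log units; beyond the scatter) from compound 1 to compound 3 and a 1.7-fold lower number (0.24 log units; within the scatter) from compound 2 to compound 4, 150-fold (2.17 log units) apart, beyond the scatter of two such steps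

The two changes are therefore not independent across these four compounds, but this rests on a single set of four and does not show what underlies the difference or how other changes would carry over.

The compounds shown leave open whether the low number of compound 1 needs methyl and 3,5-dimethoxyphenyl together. A chlorine or an ethyl group in place of that methyl would bear on this.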